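Swapping phenyl for chloropyridinyl on the amide nitrogen

The source may hold more compounds than are shown below. What is called first, only, known or untested is meant among the compounds shown, and "the series" means these compounds.

Measured so far:
compound 1 `O=C(Nc1ccccc1)c1c(O)c2cccnc2n(-c2ccccc2)c1=O`: 4.6%
compound 2 `Cc1cccc(NC(=O)c2c(O)c3cccnc3n(-c3ccccc3)c2=O)c1`: 14.2%
compound 3 `O=C(Nc1cccc(Cl)c1)c1c(O)c2cccnc2n(-c2ccccc2)c1=O`: 7.6%

All three were tested in a functional assay on the whole organism for inhibition, with Rattus norvegicus as the target, read by paw edema, at a dose of 100 mg/kg by the oral route; a lower number here means less inhibition, a higher number more inhibition at the dose given (going by the name of the read-out). Compound 1 gives the lowest of the three numbers, but its distance to compound 3 a number 3 percentage points higher from compound 1 to compound 3 (within the scatter) and to compound 2 a number 9.6 percentage points higher from compound 1 to compound 2 (within the scatter) both lie within the scatter, so no order among them can be claimed.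

Compound 4 `O=C(Nc1ccc(Cl)nc1)c1c(O)c2cccnc2n(-c2ccccc2)c1=O` has not yet been measured. It differs from compound 1 in one place: 6-chloropyridin-3-yl in place of phenyl on an amide-type nitrogen. Among the compounds with values here, the steps that bear on this are those which also alter the group on the amide-type nitrogen: methyl in place of hydrogen a number 9.6 percentage points higher from compound 1 to compound 2 (within the scatter), chloro in place of hydrogen a number 3 percentage points higher from compound 1 to compound 3 (within the scatter), and chloro in place of methyl a number 6.6 percentage points lower from compound 2 to compound 3 (within the scatter). None of them leaves the scatter. From this, the expected step in this assay is small, a number 3.4 percentage points higher from compound 1 to compound 4 (within the scatter), with no direction claimed beyond the scatter. Compound 4 is therefore estimated at 8%, within a range from 0% to 20%.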

Compound 4, a percentage reported as inhibition, in the whole organism at one dose (the size of the read-out at that dose, not a potency): 9.2%
Estimate against measurement, compound 4: 1.2 percentage points below; the range from low to high includes it.
By their numbers in this assay, from the lowest: compounds 1, 3, 4 and 2 (each within the scatter of the next).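

The earlier compounds shown here changed only a small group on the phenyl ring, whereas here the ring itself changes, gaining a hetero atom and a hydrogen-bond acceptor, and in this assay the result is a number 4.6 percentage points higher from compound 1 to compound 4 (within the scatter) on this change at the amide-type nitrogen. The comparisons with the substituted phenyl compounds read the same way, with a number 1.6 percentage points higher from compound 3 to compound 4 (within the scatter) and a number 5 percentage points lower from compound 2 to compound 4 (within the scatter), so this new ring cannot be told apart from any of the three phenyl-type groups in this read-out. No measurement offers an explanation for how close these numbers lie.

As far as these compounds go, the chloro group and the ring nitrogen enter together, so the effect of each alone remains unknown, and an unsubstituted pyridin-3-yl group would be needed to separate them. Also open, from the compounds shown here alone, is whether a group of another kind on this nitrogen, such as a carboxylic acid on the ring or a longer alkyl chain in place of the ring, would give a step beyond the scatter.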